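The source may hold more compounds than are shown below. What is called first, only, known or untested is meant among the compounds shown, and "the series" means these compounds.

Compound 1 `O=C1CC2(N3CCCC3)CC(c3ccccc3)C1C(c1ccccc1)C2`: 26500 nM
Compound 2 `O=C1CC2(N3CCCCC3)CC(c3ccccc3)C1C(c1ccccc1)C2`: 46900 nM
Compound 3 `O/N=C1\CC2(N3CCCC3)CC(c3ccc(Cl)cc3)C1C(c1ccc(Cl)cc1)C2`: 12700 nM

All three were measured in an ADME assay on L6 cells (Rattus norvegicus) for cytotoxicity; on this read-out higher numbers stand for weaker inhibition and lower numbers for stronger inhibition. Compound 1 and compound 2 share a core and differ only by piperidin-1-yl in place of pyrrolidin-1-yl on a saturated ring carbon, which gave a 1.8-fold higher number from compound 1 to compound 2 (0.25 log units; within the scatter). Compound 3 rests on a different core; how the two cores differ is not broken down here. Of the three, compound 3 gives the lowest number.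

Compound 4 `O/N=C1\CC2(N3CCCCC3)CC(c3ccc(Cl)cc3)C1C(c1ccc(Cl)cc1)C2` is still unmeasured. It differs from compound 3 by piperidin-1-yl in place of pyrrolidin-1-yl on a saturated ring carbon. The surroundings are not identical: the place lies two ring bonds from the ring atom that bears a phenyl group in compound 1, but a 4-chlorophenyl group in compound 3, so this is the same kind of change, not the same one. The step is expected to be a 1.7-fold higher number from compound 3 to compound 4 (0.24 log units; within the scatter), because the same kind of change gave a 1.8-fold higher number from compound 1 to compound 2 (0.25 log units; within the scatter). Compound 4 is therefore estimated at 22000 nM, between 9000 nM and 50000 nM.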

Compound 4, half-maximal inhibitory concentration: 8750 nM
Estimate against measurement, compound 4: 2.5-fold (0.40 log units) above, and the stated range ends above it.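

In this assay, piperidin-1-yl in place of pyrrolidin-1-yl on a saturated ring carbon gave a 1.5-fold lower number from compound 3 to compound 4 (0.16 log units; within the scatter). Set beside the earlier step, the change does not read differently on the two cores: the same change on two cores in this assay, a 1.8-fold higher number (0.25 log units; within the scatter) from compound 1 to compound 2 and a 1.5-fold lower number (0.16 log units; within the scatter) from compound 3 to compound 4, 2.6-fold (0.41 log units) apart, within the scatter of two such steps. This shows that in both pairs the swap stayed within the scatter, but it does not show that the change has a fixed size or direction, and two such small steps cannot establish that it transfers exactly between cores.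

The compounds shown leave open how a morpholin-4-yl group or an open-chain amine such as dimethylamino would read on a saturated ring carbon of either core. Both pairs cover only pyrrolidin-1-yl and piperidin-1-yl.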